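Working notes on compound 1, compound 2 and compound 3

This account rests on a few compounds, and the source may have more. Where it says the series, first, only, none or still open, it means among the compounds named here.

Measured so far in a functional assay on TK-10 cells (Homo sapiens) for antiproliferative activity; on this read-out higher numbers stand for weaker inhibition of growth and lower numbers for stronger inhibition of growth:
- compound 1, `CC(=O)Nc1ccc(S(=O)(=O)NNC(=O)c2cccnc2Nc2ccc(Cl)cc2)cc1`: compound 1 gives > 100000 nM, a limit of the assay.
- compound 2, `O=C(NNS(=O)(=O)c1ccc(F)cc1)c1cccnc1Nc1ccc(Cl)cc1Cl`: compound 2 gives > 100000 nM, also a limit of the assay.

Compound 1 stands at the limit of this assay and no number is known for it. Compound 2 likewise stands at that limit, so the two values show no order between them; both fall under (the limit of > 100000 nM in this assay, at which 2 of the 2 values shown sit). Going by the values given here, no step between measured compounds can be computed from such limits.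

Compound 3, `O=C(NNS(=O)(=O)c1ccc(Cl)cc1Cl)c1cccnc1Nc1ccc(Cl)cc1`, is not yet measured. Against compound 1 the change is 2,4-dichlorophenyl in place of 4-acetamidophenyl on a sulfonyl sulfur, in words: 2,4-dichlorophenyl in place of 4-acetamidophenyl on a sulfonyl sulfur. Compound 2, which also carries a halogenated phenyl on the sulfonyl sulfur and a dichlorophenyl elsewhere in the molecule, stays at the limit, and compound 1 with its acetamidophenyl stays there too.

The step expected is a number no higher from compound 1 to compound 3 (the limit leaves the size open), which is none beyond the scatter. For compound 3 the estimate is 100000 nM, in the range 30000 nM to 300000 nM, most probably reported again as a limit.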

Compound 3, concentration for total growth inhibition: 85100 nM
Beside the measured number, compound 3's estimate is 1.2-fold (0.07 log units) above it, within the range that was stated.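

In this assay, going by these compounds alone, compound 3 gives 85100 nM, the first actual number in this set, so the group on the sulfonyl sulfur now has one measured point rather than limits alone. Placing 2,4-dichlorophenyl in place of 4-acetamidophenyl on a sulfonyl sulfur gives an at least 1.1-fold lower number from compound 1 to compound 3 (0.07 log units; that floor lies within the scatter), which shows that the dichlorinated group at least brings the value into the measurable range, but does not establish a gain beyond the scatter, and the true size of the step remains unknown. The set as a whole still lies at or close to the top of the measurable range: the limit of > 100000 nM in this assay, at which 2 of the 3 values shown sit.

As far as these compounds go, it remains open whether another group on the sulfonyl sulfur, such as 4-chlorophenyl, 4-methoxyphenyl, a plain methyl or a phenyl bearing an amine or a carboxylic acid, would move the number clearly beyond the scatter. Within the data shown here, compound 2 differs from compound 3 in more than one place, so no step between them can be read, and the separate contribution of each chlorine in the 2,4-dichlorophenyl group also remains unresolved.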